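Notes on compound 4: fluoro for methoxy

This account rests on a few compounds, and the source may have more. Where it says the series, first, only, none or still open, it means among the compounds named here.

compound 1 `Cc1ccc(-c2ccnc(C(=O)Nc3ccc(Oc4ccnc5[nH]ccc45)cc3)n2)cc1`: in a functional assay on A549 cells (Homo sapiens) for cytotoxicity, read by MTT assay, with a stated time of 72 h (a lower number here means a stronger inhibitor, a higher number a weaker inhibitor), compound 1 gives 2380 nM
compound 2 `O=C(Nc1ccc(Oc2ccnc3[nH]ccc23)cc1)c1nccc(-c2cccc(Cl)c2)n1`: compound 2 gives 4120 nM
compound 3 `COc1ccc(-c2cc(C(=O)Nc3ccc(Oc4ccnc5[nH]ccc45)cc3)ncn2)cc1`: compound 3 gives 4410 nM

Compound 3 carries the highest of the three numbers, but its gap to compound 2 and its gap to compound 1 are both within the scatter, so the three cannot be ranked. Compound 4 `O=C(Nc1ccc(Oc2ccnc3[nH]ccc23)cc1)c1cc(-c2ccc(F)cc2)ncn1` differs from compound 3 by fluoro in place of methoxy on an aromatic carbon. Among the compounds with values here, no measured step swaps this group. Within the data shown here, the only measured step, a 1.7-fold higher number from compound 1 to compound 2 (0.24 log units; within the scatter), changes a group on the same kind of ring and stays within the scatter, and all three values sit within the scatter of one another. The expected step of a 1.1-fold lower number from compound 3 to compound 4 (0.04 log units; within the scatter) is therefore none beyond the scatter. Compound 4 is estimated at 4000 nM, with a range from 1500 nM to 11000 nM.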

Compound 4, half-maximal inhibitory concentration: 13000 nM
The estimate for compound 4 lay 3.3-fold (0.51 log units) below the measured number; measured number outside the range, above it.
By their numbers in this assay, from the lowest: compounds 1, 2 and 3 (each within the scatter of the next); then compound 4.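

In this assay, within the data shown here, the change from 4-methoxyphenyl to 4-fluorophenyl gives a 2.9-fold higher number from compound 3 to compound 4 (0.47 log units; beyond the scatter) as the only step beyond the scatter. This position, on an aromatic carbon para to a large group, therefore responds to the group it carries, which compounds 1, 2 and 3, all within the scatter of one another, could not show. No measurement at hand accounts for this step.

Going by these compounds, how an amine or a carboxylic acid at this position would read remains open. So does whether fluoro in place of methoxy gives a similar step on the core of compound 1.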